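This account rests on a few compounds, and the source may have more. Where it says the series, first, only, none or still open, it means among the compounds named here.

Compound 1 `O=C1NCCC12CCN(c1c(-c3ccc4scnc4c3)cnc3[nH]ccc13)CC2` gives 14 nM in an assay on cells for binding affinity to Cyclin-C/Cyclin-dependent kinase 19 (Homo sapiens), read by LanthaScreen; on this read-out higher numbers stand for weaker inhibition and lower numbers for stronger inhibition. Compound 2 `O=C1NCCC12CCN(c1c(-c3ccc4ncnn4c3)cnc3[nH]ccc13)CC2` gives 1020 nM in this assay.

Of these two, compound 2 stands at the higher number, the step of a 73-fold higher number from compound 1 to compound 2 (1.86 log units; beyond the scatter) lying beyond the scatter. Compound 3 `O=C1NCCC12CCN(c1c(-c3ccc4[nH]cnc4c3)cnc3[nH]ccc13)CC2` differs from compound 2 by a group of 9 heavy atoms (7 carbon, 2 nitrogen; one five-membered aromatic ring with 2 hetero atoms, one six-membered aromatic ring of carbon only) in place of a group of 9 heavy atoms (6 carbon, 3 nitrogen; one five-membered aromatic ring with 3 hetero atoms, one six-membered aromatic ring with 1 hetero atom), on an aromatic carbon. Going by the values given here, only the step from compound 1 to compound 2 bears on this change; it was large, and the group entering in compound 3 resembles the group of compound 1 more than that of compound 2. A move toward a lower number in this assay is therefore expected, the expected step being a 20-fold lower number from compound 2 to compound 3 (1.31 log units; beyond the scatter). Compound 3 is estimated at 50 nM, with a range from 8 nM to 300 nM.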

Compound 3, half-maximal inhibitory concentration: 17 nM
Compound 3: the middle estimate sits 2.9-fold (0.47 log units) above what was measured; low and high end bracket the measured number.
By their numbers in this assay, from the lowest: compounds 1 and 3 (each within the scatter of the next); then compound 2.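

In this assay, the step of a 60-fold lower number from compound 2 to compound 3 (1.78 log units; beyond the scatter) shows that 1H-benzimidazol-5-yl on this aromatic carbon brings the number back to the level of compound 1. The step of a 1.2-fold higher number from compound 1 to compound 3 (0.08 log units; within the scatter) lies within the scatter, so 1H-benzimidazol-5-yl and 1,3-benzothiazol-5-yl cannot be told apart here, and the ring sulfur of compound 1 is not needed at this position.

No data given here explain these differences. As far as these compounds go, it remains open whether a six-membered ring of carbon only is what counts, and how an indol-5-yl or a quinolin-6-yl group would read here.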